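A few compounds are considered here, and "the series" means these few. Any claim that something is new, unique, unknown or untested is made for them only; others in the source may bear on it.

Working notes on the series in a functional assay on MCF7 cells (Homo sapiens) for antiproliferative activity, read by MTT assay, with a stated time of 72 h; a higher number here means a weaker inhibitor, a lower number a stronger inhibitor. Compound 1 `C=CC/N=C1\S/C(=C\c2ccc(OC)cc2)C(=O)N1C` reads > 100000 nM, which is a limit of the assay. Compound 2 `C=C1CN/C(=N/c2ccccc2)S1` reads > 100000 nM, also a limit. For the measured compounds named here, compound 3 `COc1ccc(/C=C2\S/C(=N\c3ccc(Cl)cc3)N(C)C2=O)cc1` gives 39300 nM, the only actual number so far.

Compound 4 `COc1ccc(/C=C2\S/C(=N\c3ccc(C)c(Cl)c3)N(C)C2=O)cc1` differs from compound 3 as follows: 3-chloro-4-methylphenyl in place of 4-chlorophenyl on a double-bonded nitrogen, with 3-chloro-4-methylphenyl in place of 4-chlorophenyl on a double-bonded nitrogen. Going by the values given here, one measured step bears on this place: an at least 2.5-fold lower number from compound 1 to compound 3 (0.40 log units; beyond the scatter), beyond the scatter and open-ended. That step swaps allyl for 4-chlorophenyl, so it says nothing direct about changes within the aryl group. No shift beyond the scatter is therefore expected in this assay. The expected change is a 1.3-fold lower number from compound 3 to compound 4 (0.12 log units; within the scatter). Compound 4 is estimated at 30000 nM, within an expected range of 10000 nM to 85000 nM.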

Compound 4, half-maximal inhibitory concentration: > 100000 nM
Compound 4: only a limit was reported; the forecaster's own chance of this, stated with the estimate: 20%; middle value at least 3.3-fold (0.52 log units) away from the limit.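

In this assay, 3-chloro-4-methylphenyl in place of 4-chlorophenyl on the double-bonded nitrogen gives an at least 2.5-fold higher number from compound 3 to compound 4 (0.40 log units; beyond the scatter), so changes within the aryl group matter here, not only the swap of allyl for an aryl group. The step between compound 1 and compound 4 cannot be read, as both values are limits. Compound 3 remains the only compound with an actual number, and the true size of the step stays unknown: the limit of > 100000 nM in this assay, at which 3 of the 4 values shown sit.

It remains open which part of the 3-chloro-4-methylphenyl group accounts for the step. Also open, on these data alone, is how an amine or a carboxylic acid on the aryl group would read.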